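A few compounds are considered here, and "the series" means these few. Any claim that something is new, unique, unknown or untested is made for them only; others in the source may bear on it.

Measured compounds:
compound 1 `O=C(Nc1ccnnc1)c1cc(N2CCC(F)CC2)ccc1OCc1ccccc1` — 5.5 mL.min-1.g-1
compound 2 `O=C(Nc1ccnnc1)c1cc(N2CCC(CO)CC2)ccc1OCc1ccccc1` — 1 mL.min-1.g-1
compound 3 `O=C(Nc1ccnnc1)c1cc(N2CCC(O)CC2)ccc1OCc1ccccc1` — 0.6 mL.min-1.g-1

In an ADME assay on microsomes from liver (Homo sapiens) for metabolic stability (on this read-out lower numbers stand for slow clearance and higher numbers for fast clearance), compound 3 gives the lowest of the three numbers, though its gap to compound 2 is within the scatter; only compound 1 stands clearly apart, as a 9.2-fold lower number from compound 1 to compound 3 (0.96 log units; beyond the scatter) shows. Compound 4 `N#CC1CCN(c2ccc(OCc3ccccc3)c(C(=O)Nc3ccnnc3)c2)CC1` differs from compound 3 by cyano in place of hydroxy on a saturated ring carbon. The step that bears on this is the reverse of a 9.2-fold lower number from compound 1 to compound 3 (0.96 log units; beyond the scatter), where removing the hydroxy in favour of fluoro raised the number, and a 5.5-fold lower number from compound 1 to compound 2 (0.74 log units; beyond the scatter) points the same way. Since cyano is neither hydroxy nor fluoro, a modest rise in this assay is expected for compound 4, estimated at 2 mL.min-1.g-1 (range 0.8 mL.min-1.g-1 to 5 mL.min-1.g-1), so that the estimated step is a 3.3-fold higher number from compound 3 to compound 4 (0.52 log units; beyond the scatter).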

Compound 4, intrinsic clearance in microsomes: 5.5 mL.min-1.g-1
Estimate against measurement, compound 4: 2.8-fold (0.44 log units) below; the whole stated range lies below it.
By their numbers in this assay, from the lowest: compounds 3 and 2 (each within the scatter of the next); then compounds 1 and 4 (each within the scatter of the next).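

In this assay, cyano on this saturated ring carbon loses the low numbers seen with the two hydroxy-bearing groups, with a 9.2-fold higher number from compound 3 to compound 4 (0.96 log units; beyond the scatter) and a 5.5-fold higher number from compound 2 to compound 4 (0.74 log units; beyond the scatter). Fluoro and cyano cannot be told apart at this position, with no change at the digits printed from compound 1 to compound 4 (within the scatter). Within the data shown here, the four compounds thus form two pairs: the two whose group holds a hydroxy sit low, the two without one sit high, and no compound goes against this split. Going by these compounds, whether an amine or a carboxylic acid on this carbon would join the low pair stays open. No measurement shown gives a reason for the split.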